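A few compounds are considered here, and "the series" means these few. Any claim that something is new, unique, unknown or untested is made for them only; others in the source may bear on it.

Compound 1: `O=C(O)Cn1c(SCCCOc2ccccc2)nc2ccccc21`; in an assay on HEK293 cells for displacement of a labelled ligand from prostaglandin D2 receptor 2 (Homo sapiens) (on this read-out higher numbers stand for weaker inhibition and lower numbers for stronger inhibition), compound 1 gives 786 nM.
Compound 2: `CCCCCCSc1nc2ccccc2n1CC(=O)O`; in this assay compound 2 gives 1360 nM.

Of these two numbers compound 2 holds the larger, yet the step of a 1.7-fold higher number from compound 1 to compound 2 (0.24 log units; within the scatter) lies within the scatter, so the two compounds cannot be told apart. Compound 3, `O=C(O)Cn1c(SCc2ccccc2Br)nc2ccccc21`, is not yet measured; its change from compound 2 is 2-bromophenyl in place of pentyl on a saturated chain carbon bound to a sulfur. Among the measured compounds shown here, the one measured step, a 1.7-fold higher number from compound 1 to compound 2 (0.24 log units; within the scatter), bears only loosely on this change and was small, so no step beyond the scatter is expected. For compound 3 the estimate is 1000 nM, with a range of 300 nM to 3500 nM. The expected step is a 1.4-fold lower number from compound 2 to compound 3 (0.13 log units; within the scatter).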

Compound 3, half-maximal inhibitory concentration: 580 nM
Compound 3: middle estimate off by 1.7-fold (0.24 log units), on the high side, and the stated range covers the measured number.
By their numbers in this assay, from the lowest: compounds 3, 1 and 2 (each within the scatter of the next, the first and the last beyond it).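

In this assay, among the compounds shown here, putting 2-bromophenyl in place of pentyl on a saturated chain carbon bound to a sulfur gives a 2.3-fold lower number from compound 2 to compound 3 (0.37 log units; beyond the scatter) and so is the first step here to clear the scatter, though only modestly. This position therefore responds to the group it carries, and an aromatic ring with a bromine is accepted there. No measurement on hand explains this shift.

From the compounds shown here alone, the change brings in the ring and the bromine together, so their separate shares remain unknown. A plain phenyl or a methoxy group in place of the bromine would be needed to separate them.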